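Methoxy added ortho on the aminophenyl chalcone pyrazole

The source may report more compounds than this note shows. Statements on the series, on what has been measured and on what is new or still open speak of the compounds shown alone.

Measured so far in a functional assay on RPMI-8226 cells (Homo sapiens) for inhibition, read by sulforhodamine B assay, with a stated time of 48 h; a lower number here means a stronger inhibitor of growth, a higher number a weaker inhibitor of growth:
compound 1 `COc1ccc(-c2cc(/C=C/C(=O)c3ccc(N)cc3)[nH]n2)cc1` gives 600 nM
compound 2 `COc1ccc(C(=O)/C=C/c2cc(-c3cc(OC)c(OC)c(OC)c3)n[nH]2)cc1OC` gives 240 nM
compound 3 `COc1ccc(C(=O)/C=C/c2cc(-c3cc(OC)c(OC)c(OC)c3)n[nH]2)cc1` gives 430 nM

Compound 1 sits at the high end of the three numbers in this assay; its gap to compound 3 lies within the scatter, its gap to compound 2 beyond it. Compound 4 `COc1ccc(-c2cc(/C=C/C(=O)c3ccc(N)cc3)[nH]n2)cc1OC` is not yet measured and differs from compound 1 by methoxy in place of hydrogen on an aromatic carbon. Going by the values given here, the one measured step that bears on it runs the opposite way: a 1.8-fold higher number from compound 2 to compound 3 (0.25 log units; within the scatter), within the scatter. Reversing that step suggests a small move towards a lower number, and no step beyond the scatter is expected for compound 4, as a 1.8-fold lower number from compound 1 to compound 4 (0.25 log units; within the scatter). Compound 4 is therefore estimated at 340 nM in this assay, with a range from 150 nM to 750 nM.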

Compound 4, concentration for 50% growth inhibition: 1280 nM
Estimate against measurement, compound 4: 3.8-fold (0.58 log units) below; the measured number lies above the stated range.
By their numbers in this assay, from the lowest: compounds 2, 3 and 1 (each within the scatter of the next, the first and the last beyond it); then compound 4.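

In this assay, methoxy in place of hydrogen on this aromatic carbon, ortho to a methoxy group, costs growth inhibition, with a 2.1-fold higher number from compound 1 to compound 4 (0.33 log units; beyond the scatter). This change therefore has no single effect across the series; its direction and size on compounds 1 and 4 do not follow from compounds 2 and 3: the same change on two cores in this assay, a 1.8-fold higher number (0.25 log units; within the scatter) from compound 2 to compound 3 and a 2.1-fold lower number (0.33 log units; beyond the scatter) from compound 4 to compound 1, 3.8-fold (0.58 log units) apart, beyond the scatter of two such steps

On these data alone, the two pairs differ in more than this one change, so what sets the difference between them stays open. Also open, as far as these compounds go, is whether fluorine, a hydroxyl group or an ethoxy group at this position would behave like methoxy.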